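The source may report more compounds than this note shows. Statements on the series, on what has been measured and on what is new or still open speak of the compounds shown alone.

Measured so far in an assay on isolated protein for inhibition of alpha-ketoglutarate-dependent dioxygenase alkB homolog 3 (Homo sapiens), read by polymerase chain reaction, with a stated time of 1 h; a lower number here means a stronger inhibitor, a higher number a weaker inhibitor:
compound 1 `Cc1[nH]n(-c2nc3cc(-c4ccccc4)ccc3[nH]2)c(=O)c1Cc1ccccc1` — 810 nM
compound 2 `Cc1[nH]n(-c2ncccn2)c(=O)c1C` — > 10000 nM

Among the compounds with values here, compound 1 `Cc1[nH]n(-c2nc3cc(-c4ccccc4)ccc3[nH]2)c(=O)c1Cc1ccccc1` is the only compound of the pair with a numeric read-out in this assay, where compound 1 gives 810 nM. For compound 2 `Cc1[nH]n(-c2ncccn2)c(=O)c1C` the assay reports only a limit, > 10000 nM, and not a number; that compound 2 sits at the limit of > 10000 nM in this assay, at which 1 of the 2 values shown sits, is all that can be said of it here.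

Compound 3 `Cc1[nH]n(-c2nc3cc(-c4ccc(Cl)cc4)ccc3[nH]2)c(=O)c1Cc1ccccc1` has not yet been measured. It differs from compound 1 by one change, chloro in place of hydrogen on an aromatic carbon, placed para to a large group on the six-membered aromatic ring of carbon only, so that the phenyl of compound 1 reads as 4-chlorophenyl in compound 3. Within the data shown here, no step between two measured compounds carries this change, so there is no measured precedent. The expectation is a small step, if any, from compound 1 to compound 3 of a 1.4-fold lower number from compound 1 to compound 3 (0.13 log units; within the scatter), not clearly beyond the scatter of this assay. Compound 3 is therefore estimated at 600 nM, with a range from 200 nM to 2000 nM.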

Compound 3, half-maximal inhibitory concentration: 1500 nM
Estimate against measurement, compound 3: 2.5-fold (0.40 log units) below; the range from low to high includes it.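

In this assay, within the data shown here, the series now has its first measured step at this position, on an aromatic carbon of a six-membered aromatic ring of carbon only, para to a large group: the change from phenyl to 4-chlorophenyl gives a 1.9-fold higher number from compound 1 to compound 3 (0.27 log units; within the scatter) and remains the only step read here. One added chlorine at this position therefore leaves the read-out indistinguishable from that of the unsubstituted phenyl, so this carbon can carry chloro with no measurable change in this assay. None of the information shown offers an explanation for this result, and the limit recorded for compound 2 does not bear on this change.

On these data alone, whether an amine, a carboxylic acid or a methoxy group on the same carbon would move the number beyond the scatter remains open, as does the outcome of placing chloro elsewhere on this ring. With one step at this position, no trend can yet be drawn, and the result says nothing about changes at other parts of the core of compound 1.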